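Thioamide-linked benzamides: antiproliferative readings and a new amine

The compounds below may be only part of what the source reports. "The series", "measured", "known", "first", "only" and "open" are said of these compounds alone.

Measured compounds:
compound 1 `CC1CCCCN1C(=S)SCc1ccc(C(=O)Nc2ccccc2N)cc1` — 42.5%
compound 2 `Nc1ccccc1NC(=O)c1ccc(CSC(=S)N2CCN(c3ccncc3)CC2)cc1` — 85.7%
compound 3 `Nc1ccccc1NC(=O)c1ccc(CSC(=S)N2CCN(c3ccccc3F)CC2)cc1` — 18.7%

Compound 1 stands second highest of the three numbers in a functional assay on A-375 cells (Homo sapiens) for antiproliferative activity, read by CCK-8 assay, with a stated time of 72 h, tested at 2 uM; a lower number here means a weaker effect, a higher number a stronger effect of the compound at the concentration tested. Compound 3 is its nearest neighbour, and compound 2 lies furthest above it. Among the measured compounds shown here, the only step that can be counted between compounds differing in one place is a number 67 percentage points lower from compound 2 to compound 3 (beyond the scatter), a large fall; it sits on an amine nitrogen in a ring, not on the thiocarbonyl carbon.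

Compound 4 `Nc1ccccc1NC(=O)c1ccc(CSC(=S)N2CCc3cc(Cl)ccc32)cc1` is not yet measured. Its change from compound 1 is 5-chloro-2,3-dihydro-1H-indol-1-yl in place of 2-methylpiperidin-1-yl on a thiocarbonyl carbon. For the measured compounds named here, no measured step bears directly on this exchange: the step from compound 2 to compound 3 concerns a different position and only shows that the part of the molecule beyond the thiocarbonyl carbon can swing the reading widely. The expected step of a number 2.5 percentage points lower from compound 1 to compound 4 (within the scatter) is therefore set near zero, with a broad range in either direction. For compound 4 the estimate in this assay is 40%, between 15% and 70%.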

Compound 4, a percentage reported as inhibition, at one concentration (the size of the read-out at that concentration, not a potency): 31.9%
Compound 4: the middle estimate sits 8.1 percentage points above what was measured; the measured number falls inside the stated range.
By their numbers in this assay, from the lowest: compound 3; then compound 4; then compound 1; then compound 2.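

In this assay, among the compounds shown here, this exchange gives the only step so far on the thiocarbonyl carbon itself: a number 10.6 percentage points lower from compound 1 to compound 4 (beyond the scatter). The step is modest, so at this position, replacing 2-methylpiperidin-1-yl with 5-chloro-2,3-dihydro-1H-indol-1-yl, which adds an aromatic ring of carbon only and a chlorine, lowers the reading without removing it, as compound 4 still gives 31.9%. Nothing available bears on why the reading moves.

On these data alone, the ring change and the chlorine arrive together in this one step, so their separate contributions remain open. A 2,3-dihydro-1H-indol-1-yl without the chlorine, or a piperidin-1-yl without the methyl, on the same thiocarbonyl carbon would be needed to pull these parts apart.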